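Ethoxycarbonyl for Hydroxymethyl: Cytotoxicity Outlook

This account rests on a few compounds, and the source may have more. Where it says the series, first, only, none or still open, it means among the compounds named here.

For the measured compounds named here, compound 3 `COc1nc2ccc(Br)cc2cc1C(c1ccccc1)n1cc(CO)nn1` stands second highest of the three cytotoxicity numbers so far; in an ADME assay on HEK293 cells (Homo sapiens) for cytotoxicity, read by sulforhodamine B assay, with a stated time of 48 h, tested at 10 uM (a lower number here means less inhibition, a higher number more inhibition at the concentration tested (going by the name of the read-out)), compound 3 gives 11.5%. Its nearest neighbour is compound 2 `CCCCCCCCc1cn(C(c2ccccc2)c2cc3cc(Br)ccc3nc2OC)nn1`, which in this assay gives 14.6%, and a number 3.1 percentage points lower from compound 2 to compound 3 (within the scatter). Furthest away is compound 1 `COc1nc2ccc(Br)cc2cc1C(c1ccccc1)n1cc(-c2ccccc2F)nn1`, which in this assay gives 3.97%, with a number 7.5 percentage points higher from compound 1 to compound 3 (within the scatter). Compound 4 `CCOC(=O)c1cn(C(c2ccccc2)c2cc3cc(Br)ccc3nc2OC)nn1` differs from compound 3 by ethoxycarbonyl in place of hydroxymethyl on an aromatic carbon. Going by the values given here, no measured step exchanges this same group; the closest comparisons are a number 10.6 percentage points higher from compound 1 to compound 2 (beyond the scatter) and a number 7.5 percentage points higher from compound 1 to compound 3 (within the scatter), both on an aromatic carbon, one beyond and one within the scatter. The expectation in this assay is therefore only a small step, a number 0.5 percentage points higher from compound 3 to compound 4 (within the scatter). Compound 4 is estimated at 12%, within a range from 4% to 22%.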

Compound 4, a percentage reported as inhibition, at one concentration (the size of the read-out at that concentration, not a potency): 2%
For compound 4 the middle estimate is 10 percentage points above the measured one; measured number below the stated range.
By their numbers in this assay, from the lowest: compounds 4, 1, 3 and 2 (each within the scatter of the next, the first and the last beyond it).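

In this assay, ethoxycarbonyl on this aromatic carbon stays within the scatter of hydroxymethyl (a number 9.5 percentage points lower from compound 3 to compound 4 (within the scatter)) and of 2-fluorophenyl (a number 2 percentage points lower from compound 1 to compound 4 (within the scatter)), while octyl stands apart (a number 12.6 percentage points lower from compound 2 to compound 4 (beyond the scatter)). Compound 4 is thus the second compound, after compound 1, whose step to octyl lies beyond the scatter, though compound 3 goes against this pattern. No evidence is available that bears on this result. On these data alone, whether an amine, a carboxylic acid or a shorter chain on this carbon would stand with octyl or with the other groups remains open.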